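Dimethylaminophenyl in place of chlorofluorophenyl: a solubility estimate

The source may hold more compounds than are shown below. What is called first, only, known or untested is meant among the compounds shown, and "the series" means these compounds.

Compound 2, `Cc1cc(NCc2ccccn2)n2ncc(-c3ccc(F)c(Cl)c3)c2n1`, was measured in a physicochemical assay for solubility, read by HPLC, using the shake flask method, measured as kinetic solubility, with a stated time of 2 h, at pH 7.4; a lower number here means a less soluble compound, a higher number a more soluble compound. In this assay compound 2 reaches only a limit of the assay, namely < 5000 nM in kinetic solubility. Compound 1, `Cc1cc(NCc2cccs2)n2nc(C)c(-c3ccccc3)c2n1`, is the other measured compound. In this assay compound 1 likewise sits at a limit, giving < 5000 nM. Both readings thus rest on (the limit of < 5000 nM in this assay, at which 2 of the 2 values shown sit), and no ordering of the two compounds can be drawn from them. Compound 3, `Cc1cc(NCc2ccccn2)n2ncc(-c3cccc(N(C)C)c3)c2n1`, has not yet been measured in this assay. It differs from compound 2 in one place: 3-(dimethylamino)phenyl in place of 3-chloro-4-fluorophenyl on an aromatic carbon. For the measured compounds named here, no measured step between compounds differing in one place is available, so no comparable pair sets the size of the change. Compound 3 is nonetheless expected to show a modest rise in this assay, an at least 1.6-fold higher number from compound 2 to compound 3 (0.20 log units; that floor lies within the scatter), with a fair chance of again stopping at the limit. The estimate for compound 3 in this assay is 8000 nM, within a range from 2000 nM to 30000 nM.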

Compound 3, solubility: 94600 nM
Estimate against measurement, compound 3: 12-fold (1.07 log units) below, and the stated range ends below it.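

In this assay, the group on this aromatic carbon proves able to move the reading: 3-(dimethylamino)phenyl in place of 3-chloro-4-fluorophenyl gives an at least 18-fold higher number from compound 2 to compound 3 (1.27 log units; beyond the scatter), the only step shown that can be read. Compound 3 is also the only compound shown whose reading is a number and not a limit of the assay. The step is a floor with no known upper end, because compound 2 stands only at a limit: the limit of < 5000 nM in this assay, at which 2 of the 3 values shown sit.

The compounds shown leave open whether the step comes with the dimethylamino group entering or with the chlorine and fluorine leaving. They also leave open how a morpholine in place of the dimethylamino group, or a phenyl carrying only a chlorine, would read at this position.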